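Swapping a cyclopropyl for two chlorines on the aniline ring

The source may report more compounds than this note shows. Statements on the series, on what has been measured and on what is new or still open speak of the compounds shown alone.

Measured so far:
- compound 1, `Cc1cc(=O)oc2cc(OCc3nc(N)nc(Nc4ccc(Cl)cc4)n3)ccc12`: 32500 nM
- compound 2, `Cc1cc(=O)oc2cc(OCc3nc(N)nc(Nc4ccc(C5CC5)cc4)n3)ccc12`: 700 nM

For the measured compounds named here, compound 2 has the lowest number of the two in an assay on COS-7 cells for agonist activity at Free fatty acid receptor 1 (Homo sapiens), read by scintillation counting and inositol phosphate accumulation, with a stated time of 90 min (a lower number here means that less compound is needed, a higher number that more compound is needed for the effect), and its only neighbour is compound 1, which sits a long way above it: a 46-fold lower number from compound 1 to compound 2 (1.67 log units; beyond the scatter). That single step, which exchanged chloro for cyclopropyl on the aromatic carbon of the outer ring, is the whole of what is known here.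

Compound 3, `Cc1cc(=O)oc2cc(OCc3nc(N)nc(Nc4ccc(Cl)c(Cl)c4)n3)ccc12`, has not yet been measured. It differs from compound 2 in one place: 3,4-dichlorophenyl in place of 4-cyclopropylphenyl on a nitrogen on an aromatic ring. Read one bond further out, the change is (4-cyclopropylphenyl)amino to (3,4-dichlorophenyl)amino.

The step from compound 1 to compound 2 bears on this directly, since it shows that chloro in place of cyclopropyl on that ring goes with a much higher number. Compound 3 brings that chloro back and adds a second one; what the second chloro does is not shown by any measured pair. The expectation is therefore a step back upward, a 13-fold higher number from compound 2 to compound 3 (1.11 log units; beyond the scatter), with the second chlorine left as the open question. Compound 3 is estimated at 9000 nM, within 2000 nM to 40000 nM.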

Compound 3, half-maximal effective concentration: 780 nM
Compound 3: middle estimate off by 12-fold (1.06 log units), on the high side; the measured number lies below the stated range.
By their numbers in this assay, from the lowest: compounds 2 and 3 (each within the scatter of the next); then compound 1.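

The second chloro turns out to matter far more than the first comparison suggested: in this assay, chloro in place of hydrogen on an aromatic carbon of the outer ring gives a 42-fold lower number from compound 1 to compound 3 (1.62 log units; beyond the scatter) and so recovers about as much as the cyclopropyl did. A low number on this ring is therefore not tied to the cyclopropyl, since exchanging 4-cyclopropylphenyl for 3,4-dichlorophenyl on the nitrogen gives a 1.1-fold higher number from compound 2 to compound 3 (0.05 log units; within the scatter) and the two groups cannot be told apart in this assay, although one carries a three-membered ring and the other two chlorines. Nothing measured here explains why the added chloro goes with so large a drop, or why two such different groups end up level.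

On these data alone, whether the second chloro can be replaced by a methyl, a methoxy or a trifluoromethyl with the same outcome remains open. So does the question of whether a ring carrying both a cyclopropyl and a chloro would reach a lower number than compound 2 and compound 3 or would simply stay level with them.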